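Aryl exchange from compound 2 to compound 3

The source may report more compounds than this note shows. Statements on the series, on what has been measured and on what is new or still open speak of the compounds shown alone.

In a functional assay on KB cells (Homo sapiens) for antiproliferative activity, read by sulforhodamine B assay, with a stated time of 3 days (a higher number here means that more compound is needed for the effect, a lower number that less compound is needed), compound 2 (`CCC1=C(O)c2c(oc(-c3ccc(OC)c(Cl)c3)cc2=O)C(CC)(CC)C1=O`) gives 24.9 uM and compound 1 (`CCC1=C(O)c2c(oc(-c3ccc(C)c(C)c3)cc2=O)C(CC)(CC)C1=O`) gives 35.5 uM on the shared core. For the measured compounds named here, the two stand level, and the only measured step is a 1.4-fold lower number from compound 1 to compound 2 (0.15 log units; within the scatter) with no further value to place them against.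

Compound 3 (`CCC1=C(O)c2c(oc(-c3cc(C)cc(C)c3)cc2=O)C(CC)(CC)C1=O`) carries 3,5-dimethylphenyl in place of the 3-chloro-4-methoxyphenyl of compound 2, on an aromatic carbon next to the ring oxygen: 3,5-dimethylphenyl in place of 3-chloro-4-methoxyphenyl on an aromatic carbon is the counted difference.

Going by the values given here, the one measured exchange at this place is a 1.4-fold lower number from compound 1 to compound 2 (0.15 log units; within the scatter) and it runs between a dimethylphenyl and the same 3-chloro-4-methoxyphenyl. Among the compounds with values here, the 3,5-dimethylphenyl group itself has no measurement yet.

The estimated step is a 1.2-fold higher number from compound 2 to compound 3 (0.08 log units; within the scatter) and so nothing beyond the scatter is expected in this assay for this exchange. For compound 3 the expected value is 30 uM (estimated range 15 uM to 60 uM).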

Compound 3, concentration for half-maximal effect: 45.5 uM
Compound 3: the middle estimate sits 1.5-fold (0.18 log units) below what was measured, within the range that was stated.
By their numbers in this assay, from the lowest: compounds 2, 1 and 3 (each within the scatter of the next).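

In this assay, this position next to the ring oxygen now has three aryl groups with values, and the exchange of 3-chloro-4-methoxyphenyl for 3,5-dimethylphenyl gives a 1.8-fold higher number from compound 2 to compound 3 (0.26 log units; within the scatter). The exchange between the two dimethylphenyl groups gives a 1.3-fold higher number from compound 1 to compound 3 (0.11 log units; within the scatter), so neither the arrangement of the two methyl groups nor the exchange of the chloro and methoxy pair for them separates these compounds beyond the scatter. No independent evidence on the source of these small differences is available for this result.

Still open, from the compounds shown here alone, is whether any group at this position can move the number beyond the scatter, for example an amine or a carboxylic acid on the aryl ring, or a longer chain in place of the methyl groups. The shown compounds also share the ethyl groups on the core, so they say nothing about exchanges there.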